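Ethyl for methyl on the benzylamine nitrogen

The compounds below may be only part of what the source reports. "The series", "measured", "known", "first", "only" and "open" are said of these compounds alone.

Compound 3 `Cc1cc(C)c(-n2c(Cl)cn3c(CN(C)Cc4ccccc4)c(C(F)(F)F)nc23)c(C)c1` gives 160 nM in an assay on cells for displacement of a labelled ligand from corticotropin-releasing factor receptor 1 (Homo sapiens), with a stated time of 100 min (a lower number here means a stronger inhibitor, a higher number a weaker inhibitor), the highest number among the three measured compounds. Compound 1 `C=CCN(CC=C)Cc1c(C(F)(F)F)nc2n(-c3c(C)cc(C)cc3C)c(Cl)cn12` gives 13 nM in this assay, and compound 2 `CCCN(Cc1c(C(F)(F)F)nc2n(-c3c(C)cc(C)cc3C)c(Cl)cn12)CC1CCC1` gives 5.3 nM. The measured steps are a 2.5-fold lower number from compound 1 to compound 2 (0.39 log units; beyond the scatter), a 12-fold higher number from compound 1 to compound 3 (1.09 log units; beyond the scatter) and a 30-fold higher number from compound 2 to compound 3 (1.48 log units; beyond the scatter); each swaps the whole amine on the saturated chain carbon bound to an aromatic carbon. Compound 4 `CCN(Cc1ccccc1)Cc1c(C(F)(F)F)nc2n(-c3c(C)cc(C)cc3C)c(Cl)cn12` differs from compound 3 by methyl in place of hydrogen on a saturated chain carbon bound to an amine nitrogen. Going by the values given here, no measured step alters only one substituent on the amine nitrogen in this way, so the bearing of the recorded steps is indirect. Among the compounds with values here, they do show that the benzyl(methyl)amino compound lags behind both the diallylamino and the (cyclobutylmethyl)(propyl)amino compounds, and the bulkier amines gave the lower numbers; with only two such comparisons this is a weak lead. In this assay compound 4 is therefore expected to land near compound 3 or somewhat lower. The step of a 1.6-fold lower number from compound 3 to compound 4 (0.20 log units; within the scatter) is expected to stay small. The estimate for compound 4 is 100 nM, with a range of 40 nM to 250 nM.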

Compound 4, inhibition constant: 350 nM
Estimate against measurement, compound 4: 3.5-fold (0.54 log units) below, outside the stated range (above it).
By their numbers in this assay, from the lowest: compound 2; then compound 1; then compound 3; then compound 4.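

In this assay, going by these compounds alone, the change of methyl to ethyl on the amine nitrogen gives a 2.2-fold higher number from compound 3 to compound 4 (0.34 log units; beyond the scatter) and is the first comparison in which only one substituent on that nitrogen changes, so this position responds to a single added methyl. Against the other two amines the gap widens, with a 66-fold higher number from compound 2 to compound 4 (1.82 log units; beyond the scatter) and a 27-fold higher number from compound 1 to compound 4 (1.43 log units; beyond the scatter) as the new steps. Benzyl(ethyl)amino now carries the highest number of the four, and compound 4 goes against the earlier hint that larger amines on this carbon give lower numbers.

From the compounds shown here alone, whether isopropyl on that nitrogen raises the number further, and whether a pyridylmethyl group in place of benzyl shows the same response to methyl and ethyl, stays open. Nothing on hand speaks to why the number rises.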